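The source may hold more compounds than are shown below. What is called first, only, known or untested is meant among the compounds shown, and "the series" means these compounds.

Measured so far:
- compound 1, `c1ccc2c(c1)CCN(c1ccnc(Nc3ccc(Oc4ncnc5ccsc45)cc3)n1)C2`: 54.9%
- compound 2, `c1cc(N2CCCC2)nc(Nc2ccc(Oc3ncnc4sccc34)cc2)n1`: 61%

In a functional assay on A549 cells (Homo sapiens) for inhibition, read by MTT assay, with a stated time of 72 h, tested at 20 uM (on this read-out higher numbers stand for more inhibition at the one concentration tested (going by the name of the read-out) and lower numbers for less inhibition), compound 1 gives 54.9%, and compound 2 gives 61%. Compound 2 has the larger of the two numbers, but its gap to compound 1 lies within the usual scatter, so the two cannot be separated on this read-out. Within the data shown here, no pair of measured compounds differs in only one place, so no step of known size is available.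

Compound 3, `c1cc(N2CCCC2)nc(Nc2ccc(Oc3ncnc4ccsc34)cc2)n1`, is still to be measured in this assay. It differs from compound 2 in a single spot: a group of 9 heavy atoms (6 carbon, 2 nitrogen, 1 sulfur; one five-membered aromatic ring with 1 hetero atom, one six-membered aromatic ring with 2 hetero atoms) in place of a group of 9 heavy atoms (6 carbon, 2 nitrogen, 1 sulfur; one five-membered aromatic ring with 1 hetero atom, one six-membered aromatic ring with 2 hetero atoms), on an oxygen on an aromatic ring. The same atoms are present, joined differently. Among the measured compounds shown here, the group that enters in compound 3 is also the one found on the oxygen in compound 1, but compound 1 differs from compound 3 elsewhere as well, so it gives no clean step.

For the measured compounds named here, with no step of this kind measured, compound 3 is expected to stay near compound 2. The expected step is a number 4 percentage points lower from compound 2 to compound 3 (within the scatter), nothing beyond the scatter. Compound 3 is estimated at 57%, within 40% to 72%.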

Compound 3, a percentage reported as inhibition, at one concentration (the size of the read-out at that concentration, not a potency): 23.2%
Compound 3: the middle estimate sits 33.8 percentage points above what was measured; the measured number lies below the stated range.
By their numbers in this assay, from the lowest: compound 3; then compounds 1 and 2 (each within the scatter of the next).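

Moving the same atoms within the group on the oxygen is enough to give a number 37.8 percentage points lower from compound 2 to compound 3 (beyond the scatter) in this assay, even though the group that leaves and the group that enters have the same heavy atoms, the same ring types and the same counts of hydrogen-bond donors and acceptors, so at this position the way the atoms are joined matters, not just which atoms are present. Among these compounds, with the group on the oxygen held constant, the amine ring on the aromatic carbon also proves to matter: pyrrolidin-1-yl in place of 1,2,3,4-tetrahydroisoquinolin-2-yl gives a number 31.7 percentage points lower from compound 1 to compound 3 (beyond the scatter), a second step beyond the scatter that no earlier pair could show. Nothing available here accounts for the size of either step.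

On these data alone, it remains open whether a morpholine ring or an open-chain dimethylamino group on that aromatic carbon would read closer to pyrrolidin-1-yl or to 1,2,3,4-tetrahydroisoquinolin-2-yl. Also open, as far as these compounds go, is whether the group on the oxygen in compound 2 would give a similar step when paired with 1,2,3,4-tetrahydroisoquinolin-2-yl, since each step here was read against only one partner.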